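The source may hold more compounds than are shown below. What is called first, only, known or untested is meant among the compounds shown, and "the series" means these compounds.

Measured in an ADME assay on MT2 cells (Homo sapiens) for cytotoxicity, read by XTT assay, with a stated time of 4 days; on this read-out lower numbers stand for higher toxicity in this test and higher numbers for lower toxicity in this test:
- compound 1 `CCn1cc(NC(=O)C(=O)Nc2ccc(Cl)cc2)cn1`: 10700 nM
- compound 2 `Cc1nc(C(NC(=O)C(=O)Nc2ccc(Cl)c(F)c2)C2CCCCN2)sc1CO`: 77800 nM
- compound 3 `Cc1nc(C(NC(=O)C(=O)Nc2ccc(Cl)c(F)c2)C2CCCCN2)sc1CCO`: > 41000 nM (a limit, not a number)

Of the two numeric values, compound 2 is the higher at 77800 nM, and the gap down to compound 1 at 10700 nM lies beyond the scatter.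

Compound 4 `Cc1nc(C(NC(=O)C(=O)Nc2ccc(F)cc2F)C2CCCCN2)sc1CO` is not yet measured. It differs from compound 2 by 2,4-difluorophenyl in place of 4-chloro-3-fluorophenyl on an amide-type nitrogen.

Among the compounds with values here, the only measured step, a step that the limit leaves unreadable from compound 2 to compound 3, has no readable size and lies on the chain, not on the amide-type nitrogen. It therefore gives no guide to this change.

In this assay the step of a 1.1-fold lower number from compound 2 to compound 4 (0.05 log units; within the scatter) is expected to stay within the scatter.

Compound 4 is estimated at 70000 nM, with an expected range of 30000 nM to 150000 nM.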

Compound 4, half-maximal cytotoxic concentration: > 110000 nM
Compound 4: no number, only a limit; the forecaster's own chance of this, stated with the estimate: 35%; at least 1.5-fold (0.19 log units) between middle value and limit.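

In this assay compound 4 carries a limit, not a number: the limit of > 110000 nM in this assay, at which 1 of the 4 values shown sits.

Within the data shown here, this gives the only readable step on the amide-type nitrogen, an at least 1.4-fold higher number from compound 2 to compound 4 (0.15 log units; that floor lies within the scatter). Swapping 4-chloro-3-fluorophenyl for 2,4-difluorophenyl therefore brings no drop in the number, while the true size of the step stays unknown and its floor does not separate the two compounds.

The step from compound 2 to compound 3 cannot be read, so the chain remains uncharted. Also open, on these data alone, is how unsubstituted phenyl, or a phenyl bearing a methoxy group or an amine, would read on this nitrogen.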